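The compounds below may be only part of what the source reports. "The series", "measured", "known", "first", "only" and "open" are said of these compounds alone.

Of the compounds shown here, three of a shared core have been measured in an in vitro functional assay on cells (Fibroblast) for agonist activity at Alpha-1B adrenergic receptor (Homo sapiens); on this read-out lower numbers stand for an effect already at smaller amounts and higher numbers for an effect only at larger amounts of compound. Compound 1 `c1ccc(-c2cn[nH]c2)c(NCC2=NCCN2)c1` gives 79.4 nM, compound 2 `CCCCn1ncnc1-c1ccccc1NCC1=NCCN1` gives 200 nM, and compound 3 `Cn1ccc(-c2ccccc2NCC2=NCCN2)n1` gives 50.1 nM. Compound 3 thus holds the lowest of the three numbers, with compound 1 nearest at a gap within the scatter and compound 2 furthest at a gap beyond it. Going by the values given here, the one step between measured compounds that differ in a single place, a 1.6-fold lower number from compound 1 to compound 3 (0.20 log units; within the scatter), stays within the scatter. Compound 4 `Cn1ncnc1-c1ccccc1NCC1=NCCN1` is now to be measured in this assay. Its change from compound 3 is 1-methyl-1H-1,2,4-triazol-5-yl in place of 1-methyl-1H-pyrazol-3-yl on an aromatic carbon. Among the compounds with values here, no measured step matches this change directly; the only related exchange of one five-membered ring for another on the same aromatic carbon, a 1.6-fold lower number from compound 1 to compound 3 (0.20 log units; within the scatter), was small, while compound 2 with its own triazole shows a higher number than compound 3. Compound 4 is therefore expected to land somewhat above compound 3, at 100 nM with a range of 40 nM to 250 nM, a step of a 2.0-fold higher number from compound 3 to compound 4 (0.30 log units; within the scatter) that is expected to stay near the edge of the scatter.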

Compound 4, half-maximal effective concentration: 39.8 nM
Compound 4: middle estimate off by 2.5-fold (0.40 log units), on the high side, and the stated range ends above it.
By their numbers in this assay, from the lowest: compounds 4, 3 and 1 (each within the scatter of the next); then compound 2.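

In this assay, a 1.3-fold lower number from compound 3 to compound 4 (0.10 log units; within the scatter) shows that this aromatic carbon tolerates the 1-methyl-1H-1,2,4-triazol-5-yl in place of the 1-methyl-1H-pyrazol-3-yl, with a third hetero atom in the ring and no change beyond the scatter; a 2.0-fold lower number from compound 1 to compound 4 (0.30 log units; within the scatter) likewise stays within it. The higher number of compound 2 therefore does not follow from the triazole itself, since a 5.0-fold lower number from compound 2 to compound 4 (0.70 log units; beyond the scatter) separates two compounds that share that ring and differ only in the chain on its nitrogen, methyl against butyl. No measurement shown here offers a reason for either finding.

The compounds shown leave open how the number moves with an ethyl or propyl chain on that nitrogen, since only the two ends are at hand. They also leave open whether a hydroxyethyl or aminoethyl chain there, or a carboxylic acid on the triazole, would be tolerated.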